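Swapping a hydroxylated aryl group for 4-ethylphenyl

The source may report more compounds than this note shows. Statements on the series, on what has been measured and on what is new or still open speak of the compounds shown alone.

Compound 1 `Cc1ccc(C2=NN(c3ccc(S(C)(=O)=O)cc3)C(=O)CC2)cc1`: 20700 nM
Compound 2 `Cc1cc(O)ccc1C1=NN(c2ccc(S(C)(=O)=O)cc2)C(=O)CC1`: > 100000 nM

In a functional assay on SK-OV-3 cells (Homo sapiens) for inhibition, read by sulforhodamine B assay, with a stated time of 48 h (a higher number here means a weaker inhibitor of growth, a lower number a stronger inhibitor of growth), compound 1 gives 20700 nM. Compound 2 gives > 100000 nM, which is a limit and not a number. Compound 2 thus stands at the limit of > 100000 nM in this assay, at which 1 of the 2 values shown sits. Within the data shown here, the only measured step is an at least 4.8-fold higher number from compound 1 to compound 2 (0.68 log units; beyond the scatter), and it comes with 4-hydroxy-2-methylphenyl in place of 4-methylphenyl.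

Compound 3 `CCc1ccc(C2=NN(c3ccc(S(C)(=O)=O)cc3)C(=O)CC2)cc1` carries 4-ethylphenyl in place of 4-hydroxy-2-methylphenyl (4-ethylphenyl in place of 4-hydroxy-2-methylphenyl on a carbon with a double bond to nitrogen). The group that came with the higher number in compound 2 therefore leaves, and the new group resembles that of compound 1, so compound 1 at 20700 nM is the better guide. A move back towards a lower number in this assay is expected, at least as large as the measured step. The estimated step is an at least 5.0-fold lower number from compound 2 to compound 3 (0.69 log units; beyond the scatter). For compound 3 the expected value is 20000 nM, with an estimated range of 8000 nM to 55000 nM.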

Compound 3, concentration for total growth inhibition: 19600 nM
Beside the measured number, compound 3's estimate is 1.0-fold (0.01 log units) above it; the range from low to high includes it.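

The earlier compounds shown here did not show how this position handles a slightly longer chain: with 4-ethylphenyl on the carbon with a double bond to nitrogen, this assay reads as it does with 4-methylphenyl, a step of a 1.1-fold lower number from compound 1 to compound 3 (0.02 log units; within the scatter). The second comparison, an at least 5.1-fold lower number from compound 2 to compound 3 (0.70 log units; beyond the scatter), shows that growth inhibition of the level seen with 4-methylphenyl returns when 4-hydroxy-2-methylphenyl leaves, and it adds a second compound that stands apart from compound 2. The value of compound 2 is a limit and not a number, so the true size of that step stays unknown: the limit of > 100000 nM in this assay, at which 1 of the 3 values shown sits.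

The compounds shown leave open whether the hydroxy or the added methyl of 4-hydroxy-2-methylphenyl goes with the weaker growth inhibition. They also leave open whether a longer chain such as butyl, or an amine on the same aromatic ring, would shift the number beyond the scatter.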